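Swapping a Methyl for a Methoxy on the Pendant Phenyl

This account rests on a few compounds, and the source may have more. Where it says the series, first, only, none or still open, it means among the compounds named here.

Measured so far in a functional assay on MCF7 cells (Homo sapiens) for cytotoxicity, read by MTT assay, with a stated time of 96 h; a lower number here means a stronger inhibitor, a higher number a weaker inhibitor:
- compound 1, `COc1cc(C(=O)c2cn(-c3ccc([N+](=O)[O-])cc3)cc2-c2ccccc2)cc(OC)c1OC`, gives 4000 nM.
- compound 2, `COc1cc(C(=O)c2cn(-c3cc(OC)c(OC)c(OC)c3)cc2-c2ccccc2)cc(OC)c1OC`, gives only a limit of the assay, > 5000 nM.
- compound 3, `COc1cc(C(=O)c2cn(-c3ccccc3)cc2-c2ccccc2C)cc(OC)c1OC`, gives 190 nM.

Compound 3 holds the lowest of the two numbers; the nearest is compound 1, and that gap lies beyond the usual scatter. For the measured compounds named here, the only step measured so far is an at least 1.2-fold higher number from compound 1 to compound 2 (0.09 log units; that floor lies within the scatter), and it changes the group on the aromatic nitrogen, where compound 2 reaches the limit described by the limit of > 5000 nM in this assay, at which 1 of the 3 values shown sits.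

Compound 4, `COc1cccc(-c2cn(-c3ccccc3)cc2C(=O)c2cc(OC)c(OC)c(OC)c2)c1`, is the next compound to be tested in this assay. Its change from compound 3 is 3-methoxyphenyl in place of 2-methylphenyl on an aromatic carbon. Going by the values given here, none of the measured steps touches that carbon, so there is no direct guide; the one known step concerns a different position and says nothing about this one. A small step in this assay is therefore expected, in either direction, most likely staying close to compound 3. The estimate for compound 4 is 400 nM, with a range from 120 nM to 1500 nM, which means an expected step of a 2.1-fold higher number from compound 3 to compound 4 (0.32 log units; beyond the scatter).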

Compound 4, half-maximal inhibitory concentration: 180 nM
Compound 4: middle estimate off by 2.2-fold (0.35 log units), on the high side; the measured number falls inside the stated range.
By their numbers in this assay, from the lowest: compounds 4 and 3 (each within the scatter of the next); then compound 1. At a limit, above all of these: compound 2.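

In this assay, replacing the 2-methylphenyl with the 3-methoxyphenyl on this aromatic carbon leaves the number unchanged within the scatter: a 1.1-fold lower number from compound 3 to compound 4 (0.02 log units; within the scatter). For the compounds shown here, the only earlier step concerned the group on the aromatic nitrogen, so this is the first evidence that the carbon can accept a different substituted phenyl ring, here one carrying an added oxygen and a hydrogen-bond acceptor, without a measurable change in this assay. The data show only that these two groups cannot be told apart here, and nothing measured among these compounds explains that match.

The step alters both the substituent and its printed number in the group's name, so it cannot show whether the methyl or methoxy group itself, or its place on the phenyl ring, matters, and a 3-methylphenyl or a 2-methoxyphenyl would separate those two changes. As far as these compounds go, it also remains open whether this carbon would tolerate something much different from a substituted phenyl ring, such as an amine, a carboxylic acid or a longer alkyl chain.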